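Methyl to Methoxy on the Aromatic Ring of Compound 1

The source may report more compounds than this note shows. Statements on the series, on what has been measured and on what is new or still open speak of the compounds shown alone.

Measured compounds in a functional assay on SW1573 cells (Homo sapiens) for inhibition, read by sulforhodamine B assay, with a stated time of 48 h; a higher number here means a weaker inhibitor of growth, a lower number a stronger inhibitor of growth:
compound 1 `COC(=O)[C@@]1(C)CCC=C2[C@@H]1CC[C@@H](C)[C@]2(C)Cc1c[nH]c2ccc(C)cc12` gives 15000 nM
compound 2 `COC(=O)[C@@]1(C)CCC=C2[C@@H]1CC[C@@H](C)[C@]2(C)Cc1c[nH]c2ccc(Cl)cc12` gives 11000 nM

Among the compounds with values here, compound 1 stands at the highest of these two numbers, and its only neighbour is compound 2; the single measured step, a 1.4-fold lower number from compound 1 to compound 2 (0.13 log units; within the scatter), lies within the scatter. Compound 3 `COC(=O)[C@@]1(C)CCC=C2[C@@H]1CC[C@@H](C)[C@]2(C)Cc1c[nH]c2ccc(OC)cc12` differs from compound 1 by methoxy in place of methyl on an aromatic carbon. Within the data shown here, no measured step exchanges methyl for methoxy, but the one change made at the same aromatic carbon, a 1.4-fold lower number from compound 1 to compound 2 (0.13 log units; within the scatter), moved the number only within the scatter. For compound 3 no step beyond the scatter is therefore expected in this assay, a 1.2-fold lower number from compound 1 to compound 3 (0.06 log units; within the scatter). Compound 3 is estimated at 13000 nM, with a range from 5000 nM to 35000 nM.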

Compound 3, concentration for 50% growth inhibition: 1300 nM
Compound 3: middle estimate off by 10-fold (1.00 log units), on the high side; the whole stated range lies above it.
By their numbers in this assay, from the lowest: compound 3; then compounds 2 and 1 (each within the scatter of the next).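

Methoxy on this aromatic carbon gives a clearly stronger inhibitor of growth in this assay (a 12-fold lower number from compound 1 to compound 3 (1.06 log units; beyond the scatter)), so the position does respond to the group it carries, which the exchange of methyl for chloro did not show. The step from chloro is also beyond the scatter (an 8.5-fold lower number from compound 2 to compound 3 (0.93 log units; beyond the scatter)), so replacing methyl is not enough on its own: among these three groups, only methoxy stands apart. Nothing measured here accounts for this difference.

On these data alone, whether a hydroxyl group, an ethoxy group or an amine on the same carbon would match methoxy stays open.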